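Removing an acetyl group from a pyrazolopyridine side chain

The compounds below may be only part of what the source reports. "The series", "measured", "known", "first", "only" and "open" are said of these compounds alone.

Of the compounds shown here, three have been measured in a functional assay on THP-1 cells (Homo sapiens) for cytotoxicity, tested at 10 uM; on this read-out lower numbers stand for less inhibition and higher numbers for more inhibition at the one concentration tested (going by the name of the read-out). Compound 1 `COC[C@H](O)[C@@H](OC)[C@@H](OC)C1=CC2C(C)=NN(C)C2N=C1` gives 5%, compound 2 `CCO[C@@H](C1=CC2C(c3ccc(O)cc3)=NN(c3ccccc3)C2N=C1)[C@H](O)[C@@H](O)CO` gives 5%, and compound 3 `CCn1ncc2cc(CCCOC(C)=O)cnc21` gives 13%. All three numbers are low, and the gaps between compound 3 and either of the others lie within the usual scatter, so compound 3 stands alongside them rather than apart. Compound 4 `CCn1ncc2cc(CCCO)cnc21` differs from compound 3 in one place: hydrogen in place of acetyl on an oxygen on a saturated carbon. Going by the values given here, no measured pair shows this change, so nothing in the data points to a step beyond the scatter. Compound 4 is therefore expected to give 10%, with a range from 0% to 25%. The step of a number 3 percentage points lower from compound 3 to compound 4 (within the scatter) is expected to fall within the scatter.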

Compound 4, a percentage reported as inhibition, at one concentration (the size of the read-out at that concentration, not a potency): 8%
Estimate against measurement, compound 4: 2 percentage points above; the range from low to high includes it.
By their numbers in this assay, from the lowest: compounds 1, 2, 4 and 3 (each within the scatter of the next).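

In this assay, going by these compounds alone, the change from acetoxy to hydroxy on this side chain gives a number 5 percentage points lower from compound 3 to compound 4 (within the scatter) and is the first step that can be read between two compounds differing in one place. At this oxygen, then, acetyl and hydrogen are not told apart by this read-out. No separate measurement bears on this result.

Going by these compounds, whether an amine or a carboxylic acid in place of the hydroxy would give a step beyond the scatter remains open. The same holds for a methyl ether on this oxygen and for a longer chain.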